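Replacing the dimethylamino aryl group in compound 2

A few compounds are considered here, and "the series" means these few. Any claim that something is new, unique, unknown or untested is made for them only; others in the source may bear on it.

Measured in a functional assay on SMMC-7721 cells (Homo sapiens) for cytotoxicity, read by MTT assay, with a stated time of 72 h; on this read-out lower numbers stand for stronger inhibition and higher numbers for weaker inhibition
compound 1 `O=C1C(=Cc2ccc(O)cc2)C(=O)N(c2ccc(Cl)cc2)N1c1ccc(Cl)cc1` gives 20600 nM as a number
compound 2 `CN(C)c1ccc(C=C2C(=O)N(c3ccc(Cl)cc3)N(c3ccc(Cl)cc3)C2=O)cc1` gives > 128000 nM as a limit only
compound 3 `COc1cc(C=C2C(=O)N(c3ccc(Cl)cc3)N(c3ccc(Cl)cc3)C2=O)cc(OC)c1OC` gives 29500 nM as a number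

Compound 2 stands at the limit of > 128000 nM in this assay, at which 1 of the 3 values shown sits, and so has no number, only a limit. Compound 4 `COc1cccc(C=C2C(=O)N(c3ccc(Cl)cc3)N(c3ccc(Cl)cc3)C2=O)c1O` is still unmeasured, and its difference from compound 2 is 2-hydroxy-3-methoxyphenyl in place of 4-(dimethylamino)phenyl on a double-bonded chain carbon bound to a double-bonded ring carbon in this one place. The measured step bearing most directly on this change is an at least 6.2-fold higher number from compound 1 to compound 2 (0.79 log units; beyond the scatter) with dimethylamino in place of hydroxy on an aromatic carbon. Compound 4 also loses dimethylamino and carries a hydroxy, though in a different group, so that step is only a partial guide. Without dimethylamino, compound 1 gives 20600 nM and compound 3 gives 29500 nM as two values within the scatter of each other. In this assay a move to a lower number is therefore expected, estimated as an at least 5.1-fold lower number from compound 2 to compound 4 (0.70 log units; beyond the scatter) for this change. Compound 4 is estimated at 25000 nM as its middle value. The expected range for compound 4 runs from 8000 nM to 70000 nM on repeated measurement.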

Compound 4, half-maximal inhibitory concentration: 64900 nM
The estimate for compound 4 lay 2.6-fold (0.41 log units) below the measured number, within the range that was stated.
By their numbers in this assay, from the lowest: compounds 1 and 3 (each within the scatter of the next); then compound 4. At a limit, above all of these: compound 2.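

In this assay compound 2 has no number, only a limit: the limit of > 128000 nM in this assay, at which 1 of the 4 values shown sits.

Setting 2-hydroxy-3-methoxyphenyl in place of 4-(dimethylamino)phenyl on a double-bonded chain carbon bound to a double-bonded ring carbon gives an at least 1.9-fold lower number from compound 2 to compound 4 (0.29 log units; that floor lies within the scatter) and so yields a measurable value, though the true size of this step remains unknown. A hydroxy on the aryl group does not by itself secure the result seen with 4-hydroxyphenyl: the change to 2-hydroxy-3-methoxyphenyl gives a 3.2-fold higher number from compound 1 to compound 4 (0.50 log units; beyond the scatter) and shows that the two hydroxy-bearing groups are not interchangeable here.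

From the compounds shown here alone, it remains open whether the hydroxy or the methoxy within 2-hydroxy-3-methoxyphenyl accounts for that step. Also open, going by these compounds, is how a primary amine or a carboxylic acid on the aryl ring would read in this assay on this shared core.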